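Aryl change on compound 3: working notes

A few compounds are considered here, and "the series" means these few. Any claim that something is new, unique, unknown or untested is made for them only; others in the source may bear on it.

Compound 1 `CC1(C)Oc2ccc(C#N)cc2[C@@H](NC(=O)c2ccccc2)[C@@H]1O`: 30 nM
Compound 2 `CC1(C)Oc2ccc(C#N)cc2[C@@H](NC(=O)Nc2ccncc2)[C@@H]1O`: 8500 nM
Compound 3 `CC1(C)Oc2ccc(C#N)cc2[C@@H](/N=C(\NC#N)Nc2cccc([N+](=O)[O-])c2)[C@@H]1O`: 670 nM

All three were measured in a functional assay (aorta) with Rattus norvegicus as the target; a lower number here means a stronger inhibitor, a higher number a weaker inhibitor. Compound 3 holds the second highest of the three numbers: compound 3 gives 670 nM, while compound 2 gives 8500 nM and compound 1 gives 30 nM. Among the compounds with values here, the only recorded step, a 280-fold higher number from compound 1 to compound 2 (2.45 log units; beyond the scatter), concerns the group on the carbonyl carbon and therefore does not bear on the present change. Compound 4 `CC1(C)Oc2ccc(C#N)cc2[C@@H](/N=C(\NC#N)Nc2ccc(Cl)c(Cl)c2)[C@@H]1O` differs from compound 3 by 3,4-dichlorophenyl in place of 3-nitrophenyl on an amine nitrogen. Within the data shown here, no measured step touches the group on the amine nitrogen, so nothing predicts a shift beyond the scatter. Compound 4 is therefore expected near 600 nM, with a range from 150 nM to 2500 nM. The expected step of a 1.1-fold lower number from compound 3 to compound 4 (0.05 log units; within the scatter) is estimated to remain within the scatter.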

Compound 4, half-maximal inhibitory concentration: 4600 nM
The estimate for compound 4 lay 7.7-fold (0.88 log units) below the measured number; measured number above the stated range.
By their numbers in this assay, from the lowest: compound 1; then compound 3; then compounds 4 and 2 (each within the scatter of the next).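

On the amine nitrogen of the cyanoguanidine-type series, the aryl group is not interchangeable: in this assay, 3,4-dichlorophenyl in place of 3-nitrophenyl gives a 6.9-fold higher number from compound 3 to compound 4 (0.84 log units; beyond the scatter) on the otherwise unchanged structure. Within the data shown here, this is the first reading of a change at this place, and its step lies beyond the scatter. No supporting measurement bears on the origin of this shift.

On these data alone, the swap removes the nitro group and adds two chlorines together, so the contribution of each remains open. As far as these compounds go, an unsubstituted phenyl, a single chlorine or a methoxy group on this ring also remains open.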